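Adding a Hydroxyl Arm to a Small Amide

The compounds below may be only part of what the source reports. "The series", "measured", "known", "first", "only" and "open" are said of these compounds alone.

Compound 1 `CNC(=O)CC1CCc2cc(OC)c(OC)cc21` carries a methylamino group on a carbonyl carbon. In a functional assay on the whole organism (strain Wistar) for inhibition, with Rattus norvegicus as the target, read by paw edema, with stated times of 60 min and 24 h, at a dose of 100 mg/kg by the oral route (on this read-out lower numbers stand for less inhibition and higher numbers for more inhibition at the one dose given (going by the name of the read-out)), compound 1 gives 33.3%, the higher of the two numbers measured. Within the data shown here, compound 2 `CCN(CC)C(=O)CC1CCc2cc(OC)c(OC)cc21` gives 16.7%, and the single measured step, a number 16.6 percentage points lower from compound 1 to compound 2 (beyond the scatter), came with diethylamino in place of methylamino on that carbonyl carbon. Compound 3 `COc1cc2c(cc1OC)C(CC(=O)NCCO)CC2` differs from compound 1 by hydroxymethyl in place of hydrogen on a saturated chain carbon bound to an amide-type nitrogen. Among the measured compounds shown here, only that step to compound 2 bears on this change, and it was modest and downward. A smaller drop, or none beyond the scatter, is therefore expected, a number 8.3 percentage points lower from compound 1 to compound 3 (within the scatter). Compound 3 is estimated at 25%, between 10% and 40%.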

Compound 3, a percentage reported as inhibition, in the whole organism at one dose (the size of the read-out at that dose, not a potency): 13.3%
Estimate against measurement, compound 3: 11.7 percentage points above; the range from low to high includes it.
By their numbers in this assay, from the lowest: compounds 3 and 2 (each within the scatter of the next); then compound 1.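

Putting hydroxymethyl in place of hydrogen on a saturated chain carbon bound to an amide-type nitrogen gives, in this assay, a number 20 percentage points lower from compound 1 to compound 3 (beyond the scatter). Both replacements of methylamino shown here therefore go with a lower number, whether the new group is diethylamino or (2-hydroxyethyl)amino, and the comparison between those two gives a number 3.4 percentage points lower from compound 2 to compound 3 (within the scatter). Nothing available explains the drop. Still open, going by these compounds, is whether the hydroxyl matters at all or any larger group does the same. Ethylamino, (2-methoxyethyl)amino or a chain ending in an amine would help separate these possibilities.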